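Swapping a Bulky Amide Group for an Aromatic One

The source may report more compounds than this note shows. Statements on the series, on what has been measured and on what is new or still open speak of the compounds shown alone.

Three compounds sharing one core were tested in a functional assay on HeLa cells (Homo sapiens) for cytotoxicity, read by MTT assay, with a stated time of 24 h; on this read-out higher numbers stand for weaker inhibition and lower numbers for stronger inhibition. Compound 1 `C=CC1=C(C(=O)NCc2ccc(Cl)cc2)C(c2ccc(OC)c(OC)c2)OC1` gives in this assay > 100000 nM, which is a limit of the assay rather than a number. Compound 3 `C=CC1=C(C(=O)NCc2ccc(OC)c(OC)c2)C(c2ccc(OC)cc2)OC1` likewise gives > 100000 nM in this assay, again a limit. Compound 2 `C=CC1=C(C(=O)NC(C)(C)C)C(c2ccc(OC)cc2)OC1` gives > 100000 nM in this assay, also a limit. Compound 2 thus stands exactly where compounds 1 and 3 stand, with no measured number to set it apart, as the limit of > 100000 nM in this assay, at which 3 of the 3 values shown sit, sums up. Going by the values given here, no single-change step between measured compounds exists here, so the size of any change cannot be read from the data.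

Compound 4 `C=CC1=C(C(=O)Nc2ccc(OCC)cc2)C(c2ccc(OC)cc2)OC1` differs from compound 2 in one place: 4-ethoxyphenyl in place of tert-butyl on an amide-type nitrogen. With all three measured values sitting at the limit, nothing indicates a step in either direction, and in this assay compound 4 is also expected to show little or no measurable effect. The step expected in this assay is a step that the limit leaves unreadable from compound 2 to compound 4, meaning no change beyond the scatter. Compound 4 is therefore estimated at 120000 nM, within a range from 30000 nM to 500000 nM, most likely reported again only as a limit.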

Compound 4, half-maximal inhibitory concentration: > 100000 nM
Compound 4: only a limit was reported (the forecaster's own chance of this, stated with the estimate: 75%); the middle value does not contradict the limit.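

Compound 2 and compound 4 both carry only a limit of the assay, not a number, and no step can be read between them. The compounds shown leave open whether, in this assay, any change to the amide group would give a measurable value.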